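Cyanophenyl positional isomers on the triazole-linked chromone ether

This account rests on a few compounds, and the source may have more. Where it says the series, first, only, none or still open, it means among the compounds named here.

The series shares one core, a chromone ether joined through a triazole to a substituted benzyl group. Compound 1 `O=c1ccoc2cc(OCc3cn(Cc4cccc(F)c4)nn3)ccc12` carries a 3-fluorophenyl group on that benzyl carbon. In a functional assay on SW480 cells (Homo sapiens) for cytotoxicity, read by MTT assay, with a stated time of 48 h (a lower number here means a stronger inhibitor, a higher number a weaker inhibitor), compound 1 reaches only a limit, > 100000 nM. Compound 2 `O=c1ccoc2cc(OCc3cn(Cc4cccc(Cl)c4)nn3)ccc12` has chloro in place of fluoro, and in this assay compound 2 gives 12900 nM. Compound 3 `N#Cc1ccc(Cn2cc(COc3ccc4c(=O)ccoc4c3)nn2)cc1` carries a 4-cyanophenyl group. In this assay compound 3 likewise reaches only a limit, > 100000 nM. Compound 3 therefore stands together with compound 1 at the edge of what this assay reports, as stated in the limit of > 100000 nM in this assay, at which 2 of the 3 values shown sit. The step from compound 1 to compound 2 was an at least 7.7-fold lower number from compound 1 to compound 2 (0.88 log units; beyond the scatter), the step from compound 2 to compound 3 was an at least 7.7-fold higher number from compound 2 to compound 3 (0.88 log units; beyond the scatter), and the step from compound 1 to compound 3 was a step that the two limits leave unreadable from compound 1 to compound 3.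

Compound 4 `N#Cc1cccc(Cn2cc(COc3ccc4c(=O)ccoc4c3)nn2)c1` is the unmeasured positional isomer: 3-cyanophenyl in place of 4-cyanophenyl on a saturated chain carbon bound to an aromatic nitrogen. Going by the values given here, no measured step moves a group between positions on the phenyl ring, so none bears directly on this change. Given that compound 3 sits at a limit, compound 4 is expected to remain near that limit, with the step from compound 3 to compound 4 estimated as a number no higher from compound 3 to compound 4 (the limit leaves the size open). For compound 4 the expected value is 100000 nM, within 25000 nM to 400000 nM.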

Compound 4, half-maximal inhibitory concentration: > 100000 nM
Compound 4 gave a limit, no number; the forecaster's own chance of this, stated with the estimate: 65%; the middle value sits exactly at the limit.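

Moving the nitrile from the 4-cyanophenyl to the 3-cyanophenyl group does not bring the series into a readable range in this assay: compound 4 gives > 100000 nM, which is a limit and not a number. The steps joining compound 4 to compound 3 and to compound 1 cannot be read, as each has a limit at both ends. Cyano in place of chloro on an aromatic carbon gives an at least 7.7-fold higher number from compound 2 to compound 4 (0.88 log units; beyond the scatter), a comparison of the two groups on the same ring position that the step to compound 3 did not offer, and the set still holds a single number: the limit of > 100000 nM in this assay, at which 3 of the 4 values shown sit.

The order of the two cyanophenyl isomers stays open, and so does any cause for the gap between the chloro and cyano groups, since the values show only that cyano at either position goes with a limit. Also open, as far as these compounds go, is whether the readable value of the 3-chlorophenyl group extends to other groups on that ring, such as a bromo group, an aminomethyl group or a carboxylic acid.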